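This account rests on a few compounds, and the source may have more. Where it says the series, first, only, none or still open, it means among the compounds named here.

Compound 1 `CN(C)/C=N/c1c(C=O)c(-c2ccccc2)nn1-c1ccccc1`: 9300 nM
Compound 2 `CN(C)/C=N/c1c(C=O)c(-c2ccccc2)nn1-c1cccc([N+](=O)[O-])c1`: 36700 nM
Compound 3 `COc1ccc(-n2nc(-c3ccccc3)c(C=O)c2/N=C/N(C)C)cc1`: 20200 nM

The three compounds share one core and differ only in a single group on one of their two phenyl rings. They were tested in a functional assay on NPC-TW01 cells (Homo sapiens) for inhibition, read by MTT assay, with a stated time of 72 h; on this read-out lower numbers stand for stronger inhibition of growth and higher numbers for weaker inhibition of growth. Compound 1 gives the lowest number of the three: compound 3 sits above it by a 2.2-fold higher number from compound 1 to compound 3 (0.34 log units; beyond the scatter), and compound 2 sits above it by a 3.9-fold higher number from compound 1 to compound 2 (0.60 log units; beyond the scatter). Between compound 2 and compound 3 the gap is a 1.8-fold lower number from compound 2 to compound 3 (0.26 log units; within the scatter).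

Compound 4 `COc1ccc(-c2nn(-c3ccccc3)c(/N=C/N(C)C)c2C=O)cc1` has not yet been measured. It differs from compound 1 by methoxy in place of hydrogen on an aromatic carbon. Compound 3 carries the same methoxy group, though not on the same phenyl ring as compound 4, and that addition gave a 2.2-fold higher number from compound 1 to compound 3 (0.34 log units; beyond the scatter); the other addition seen here, a nitro group, gave a 3.9-fold higher number from compound 1 to compound 2 (0.60 log units; beyond the scatter). Both additions raised the number, so for compound 4 a modest rise in this assay is expected, about a 1.7-fold higher number from compound 1 to compound 4 (0.24 log units; within the scatter). Compound 4 is therefore estimated at 16000 nM, with a likely range from 7000 nM to 40000 nM.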

Compound 4, concentration for 50% growth inhibition: 27200 nM
For compound 4 the middle estimate is 1.7-fold (0.23 log units) below the measured one; measured number inside the range.
By their numbers in this assay, from the lowest: compound 1; then compounds 3, 4 and 2 (each within the scatter of the next).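

Compound 4 is the first change shown on the phenyl ring that the earlier compounds left untouched, and 4-methoxyphenyl in place of phenyl there gives a 2.9-fold higher number from compound 1 to compound 4 (0.47 log units; beyond the scatter) in this assay. With this result, adding a group to either phenyl ring has raised the number each time, so growth inhibition has become weaker and compound 1, with no added group, still gives the lowest number of the four. No measurement offered here explains why methoxy has this effect at this position.

Methoxy is the only group shown at this position, so a single example cannot show whether any added group raises the number or only this one. An amine, a carboxylic acid or a fluorine atom in the same place could still give a different result.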